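Cytotoxicity of thiazolyl pyrazolines against mouse fibroblasts

A few compounds are considered here, and "the series" means these few. Any claim that something is new, unique, unknown or untested is made for them only; others in the source may bear on it.

The study compares three measured pyrazolines and one untested analogue in an ADME assay on NIH3T3 cells (Mus musculus) for cytotoxicity, read by XTT assay, with a stated time of 24 h; on this read-out lower numbers stand for stronger inhibition and higher numbers for weaker inhibition. Compound 1 `Fc1ccc(C2CC(c3ccc(Cl)s3)=NN2c2nc(-c3ccc(Cl)cc3)cs2)cc1` reaches only a limit of the assay, > 500 ug/mL. Compound 2 `N#Cc1ccc(-c2csc(N3N=C(c4ccc(Cl)s4)CC3c3ccc(F)cc3)n2)cc1` likewise gives a limit, > 500 ug/mL. Within the data shown here, compound 3 `Cc1ccc(C2=NN(c3nc(-c4ccc(C#N)cc4)cs3)C(c3ccc(F)cc3)C2)s1` is the one compound with a number, 250 ug/mL. Compound 3 differs from compound 2 by methyl in place of chloro on an aromatic carbon, and this gives an at least 2.0-fold lower number from compound 2 to compound 3 (0.30 log units; that floor lies within the scatter). Compound 1 differs from compound 2 by chloro in place of cyano on an aromatic carbon, and the step that the two limits leave unreadable from compound 2 to compound 1 cannot be read because of the limit of > 500 ug/mL in this assay, at which 2 of the 3 values shown sit.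

Compound 4 `Cc1ccc(C2=NN(c3nc(-c4ccc(Cl)cc4)cs3)C(c3ccc(F)cc3)C2)s1` has not been measured in this assay. It differs from compound 3 by chloro in place of cyano on an aromatic carbon, the same change that separates compound 2 from compound 1, made on the core of compound 3, which differs from the core of compound 2 by methyl in place of chloro on an aromatic carbon. Since that earlier step is not readable, the expectation for compound 4 rests on compound 3 and its value 250 ug/mL, so the step of a 1.4-fold higher number from compound 3 to compound 4 (0.15 log units; within the scatter) is expected to be small. Compound 4 is estimated at 350 ug/mL, within 150 ug/mL to 800 ug/mL, with a real chance that only a limit is reported.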

Compound 4, half-maximal inhibitory concentration: > 500 ug/mL
Compound 4 gave a limit, no number; the forecaster's own chance of this, stated with the estimate: 50%; middle value at least 1.4-fold (0.15 log units) away from the limit.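

In this assay, 4-cyanophenyl to 4-chlorophenyl on the core of compound 3 gives an at least 2.0-fold higher number from compound 3 to compound 4 (0.30 log units; that floor lies within the scatter), so only a floor for the step is known, and the change goes with a higher number on this core without that floor clearing the scatter. Compound 4 gives only a limit of the assay, > 500 ug/mL, and not a number. Whether the change has the same size on the two cores cannot be told, since neither the step from compound 2 to compound 1 nor the step from compound 1 to compound 4 can be read: the limit of > 500 ug/mL in this assay, at which 3 of the 4 values shown sit.

The compounds shown leave open how this read-out responds to an amine or a carboxylic acid in place of the cyano or chloro group. They also leave open whether a longer chain in place of the methyl on the core of compound 3 would shift the number, and whether any such pair would give two numbers that can be compared.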